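The compounds below may be only part of what the source reports. "The series", "measured", "known", "first", "only" and "open" are said of these compounds alone.

Measured compounds:
- compound 1 `CC1CCN(c2cc(C(F)(F)F)ccc2CNC(=O)C(C)c2ccc(NS(C)(=O)=O)c(F)c2)CC1`: 0.9 nM
- compound 2 `CC(C(=O)NCc1ccc(C(F)(F)F)cc1OC1CCCCC1)c1ccc(NS(C)(=O)=O)c(F)c1`: 0.7 nM

In an assay on CHO cells for antagonist activity at transient receptor potential cation channel subfamily V member 1 (Homo sapiens), read by FLIPR (a higher number here means a weaker inhibitor, a lower number a stronger inhibitor), compound 1 gives 0.9 nM and compound 2 gives 0.7 nM. Among the measured compounds shown here, compound 2 sits at one end of the two numbers, with compound 1 as its only neighbour, and the two are within the scatter of each other: the step of a 1.3-fold lower number from compound 1 to compound 2 (0.11 log units; within the scatter) amounts to no real change.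

Compound 3 `CC(C(=O)NCc1ccc(C(F)(F)F)cc1OCc1ccccc1)c1ccc(NS(C)(=O)=O)c(F)c1` is not yet measured. It differs from compound 2 in one place: benzyl in place of cyclohexyl on an oxygen on an aromatic ring. For the measured compounds named here, no measured step exchanges cyclohexyl for benzyl anywhere, so no step bears on it directly. Going by the values given here, the one step known, a 1.3-fold lower number from compound 1 to compound 2 (0.11 log units; within the scatter), exchanged the whole group on that aromatic carbon, 4-methylpiperidin-1-yl for cyclohexyloxy, and stayed within the scatter; this is the only guide and says merely that the group at this place has so far been changed without cost.

On that basis the step of a 2.1-fold higher number from compound 2 to compound 3 (0.33 log units; beyond the scatter) is expected to stay within the scatter, or at most slightly beyond it in the weaker direction. The estimate for compound 3 in this assay is 1.5 nM, with a range of 0.4 nM to 6 nM.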

Compound 3, inhibition constant: 0.9 nM
Beside the measured number, compound 3's estimate is 1.7-fold (0.22 log units) above it, and the stated range covers the measured number.
By their numbers in this assay, from the lowest: compounds 2, 1 and 3 (each within the scatter of the next).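

In this assay, an aromatic ring on this oxygen reads the same as a saturated one (a 1.3-fold higher number from compound 2 to compound 3 (0.11 log units; within the scatter)), so benzyl and cyclohexyl cannot be told apart here, although benzyl brings a carbon more and a different kind of ring. Compound 3 also cannot be told apart from the nitrogen-linked compound 1 (no change at the digits printed from compound 1 to compound 3 (within the scatter)), so 4-methylpiperidin-1-yl, cyclohexyloxy and benzyloxy on this aromatic carbon now form a single level across the three compounds shown, and the earlier single exchange is no longer an isolated case. No measurement at hand offers a reason for this flat reading.

Still open, on these data alone, is whether this aromatic carbon accepts groups of another kind, such as a primary amine, a carboxylic acid or a small methoxy, or whether a longer chain on the oxygen, such as phenethyl, stays at the same level. Also open, as far as these compounds go, is whether a fluorine or a nitrile on the benzyl ring would separate from these values, and whether the same flat reading would hold on a core other than the one shared by these three compounds.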